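The source may hold more compounds than are shown below. What is called first, only, known or untested is meant among the compounds shown, and "the series" means these compounds.

Three compounds share one core and differ only in the group on a saturated chain carbon bound to a sulfonyl sulfur. In a functional assay, read by fluorescence and spectrophotometry, with a stated time of 1 h (on this read-out higher numbers stand for an effect only at larger amounts of compound and lower numbers for an effect already at smaller amounts), compound 1 `O=S(=O)(/C=C/c1ccc(O)c(O)c1)CC1CCCC1` gives 9400 nM, compound 2 `O=S(=O)(/C=C/c1ccc(O)c(O)c1)CC1CCCCC1` gives 7500 nM, and compound 3 `CCCCCCCCS(=O)(=O)/C=C/c1ccc(O)c(O)c1` gives 6400 nM. The steps between them are small: a 1.3-fold lower number from compound 1 to compound 2 (0.10 log units; within the scatter), a 1.5-fold lower number from compound 1 to compound 3 (0.17 log units; within the scatter) and a 1.2-fold lower number from compound 2 to compound 3 (0.07 log units; within the scatter). Compound 3 thus stands among the others rather than apart from them, since each of its separations lies within the scatter, and none of the three can be set apart in this assay. Compound 4 `CCCCCCCCCS(=O)(=O)/C=C/c1ccc(O)c(O)c1` adds one carbon to the chain of compound 3: methyl in place of hydrogen on a saturated chain carbon, eight bonds along the chain from a sulfonyl sulfur. Among the measured compounds shown here, the steps that bear on this change are those altering the group on the same chain carbon, a 1.5-fold lower number from compound 1 to compound 3 (0.17 log units; within the scatter) and a 1.2-fold lower number from compound 2 to compound 3 (0.07 log units; within the scatter), both within the scatter. Compound 4 is therefore expected to show no step beyond the scatter, with a 1.1-fold lower number from compound 3 to compound 4 (0.03 log units; within the scatter) as the estimated movement. In this assay compound 4 is estimated at 6000 nM, within a range from 3000 nM to 12000 nM.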

Compound 4, half-maximal effective concentration: 7700 nM
Estimate against measurement, compound 4: 1.3-fold (0.11 log units) below; measured number inside the range.
By their numbers in this assay, from the lowest: compounds 3, 2, 4 and 1 (each within the scatter of the next).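

In this assay, methyl in place of hydrogen on a saturated chain carbon, eight bonds along the chain from a sulfonyl sulfur, gives a 1.2-fold higher number from compound 3 to compound 4 (0.08 log units; within the scatter). The earlier steps shown here exchanged one group for another on the chain carbon bound to the sulfonyl sulfur, whereas this one alters the open chain itself and adds a single carbon, and it too leaves compound 4 unseparated from compound 3. No supporting measurement is available to explain this result.

The compounds shown leave open whether a much longer chain, or an amine or a carboxylic acid at the end of the chain, would produce a step beyond the scatter. With each compound lying within the scatter of the next, they also cannot show whether the group at this position influences the read-out at all.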